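The source may report more compounds than this note shows. Statements on the series, on what has been measured and on what is new or still open speak of the compounds shown alone.

Measured in a toxicity assay on MT4 cells (Homo sapiens) for cytotoxicity, read by MTT assay, with a stated time of 5 days; a higher number here means that more compound is tolerated, a lower number that less compound is tolerated:
compound 1 (`Cc1cnc(Nc2ccc(C#N)cc2)nc1Nc1c(F)cc(-c2ccsc2)cc1F`): 261000 nM
compound 2 (`Cc1cnc(Nc2ccc(C#N)cc2)nc1Nc1c(F)cc(-c2cc(F)nc(F)c2)cc1F`): 103000 nM
compound 3 (`Cc1cc(-c2ccco2)cc(C)c1Nc1ccnc(Nc2ccc(C#N)cc2)n1`): 1700 nM

For the measured compounds named here, of these three numbers, the one for compound 3 is the lowest, and the other two lie far above it. The next compound, compound 4 (`Cc1cc(-c2cc3ccccc3s2)cc(C)c1Nc1ccnc(Nc2ccc(C#N)cc2)n1`), keeps the core of compound 3 and carries 1-benzothiophen-2-yl in place of furan-2-yl on an aromatic carbon. Going by the values given here, only one measured step bears on this exchange of one aromatic group for another, and it is an indirect guide. It is a 2.5-fold lower number from compound 1 to compound 2 (0.40 log units; beyond the scatter), a modest change on the core of compound 1, with a different pair of groups. Among the compounds with values here, no step has been measured on the core of compound 3, so direction is poorly defined. A modest step in this assay is expected, leaning upward since compound 3 at 1700 nM sits at the bottom of the set. This estimate means a 2.4-fold higher number from compound 3 to compound 4 (0.37 log units; beyond the scatter), although a change within the scatter remains possible. The expected value for compound 4 is 4000 nM, within an estimated range from 1200 nM to 20000 nM.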

Compound 4, half-maximal cytotoxic concentration: 138000 nM
Compound 4: the middle estimate sits 35-fold (1.54 log units) below what was measured; the measured number lies above the stated range.
By their numbers in this assay, from the lowest: compound 3; then compounds 2, 4 and 1 (each within the scatter of the next, the first and the last beyond it).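

In this assay, the exchange at this place, para to a large group on the core of compound 3, gives an 81-fold higher number from compound 3 to compound 4 (1.91 log units; beyond the scatter). For the compounds shown here, the only earlier exchange of aromatic groups, on another core, was far smaller at a 2.5-fold lower number from compound 1 to compound 2 (0.40 log units; beyond the scatter), so the earlier compounds did not show that a change of this kind can move the number so far. Here the heavy atoms, the oxygen-to-sulfur change and the added six-membered aromatic ring all change together, and nothing measured accounts for the size of the step.

The compounds shown leave open whether 1-benzofuran-2-yl or thiophen-2-yl at this place would stand nearer to compound 3 or to compound 4, which would separate the added ring from the hetero atom. From the compounds shown here alone, how an amine or a carboxylic acid at this place would read in this assay also remains open.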